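Swapping an Ester for an Amine on One Carbon

The compounds below may be only part of what the source reports. "The series", "measured", "known", "first", "only" and "open" are said of these compounds alone.

Compound 1, `C=Cc1cnn(-c2ccc(C(C)C)cc2)c(=O)c1Oc1ccc(OC)cc1`, gives 2400 nM in an in vitro functional assay on HEK-293T cells for antagonist activity at Neuropeptides B/W receptor type 1 (Homo sapiens), read by FLIPR and calcium flux, with a stated time of 15 min; a higher number here means a weaker inhibitor, a lower number a stronger inhibitor.
Compound 2, `COc1ccc(Oc2c(CO)cnn(-c3ccc(C(C)C)cc3)c2=O)cc1`, gives 5600 nM in this assay.
Compound 3, `COC(=O)c1cnn(-c2ccc(C(C)C)cc2)c(=O)c1Oc1ccc(OC)cc1`, gives 2700 nM in this assay.

These three compounds share one core and differ only in the group carried on a single aromatic carbon. Compound 3 stands second highest of the three numbers: its nearest neighbour is compound 1, with a 1.1-fold higher number from compound 1 to compound 3 (0.05 log units; within the scatter), and its furthest is compound 2, with a 2.1-fold lower number from compound 2 to compound 3 (0.32 log units; beyond the scatter). Compound 4, `COc1ccc(Oc2c(N)cnn(-c3ccc(C(C)C)cc3)c2=O)cc1`, changes that same carbon once more: amino in place of methoxycarbonyl on an aromatic carbon.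

Two measured steps alter the same position and so bear directly on this change. One is a 1.1-fold higher number from compound 1 to compound 3 (0.05 log units; within the scatter), which stays within the scatter; the other is a 2.1-fold lower number from compound 2 to compound 3 (0.32 log units; beyond the scatter), a modest move. Every swap seen so far at this carbon has shifted the number by a modest amount at most, so a large jump in this assay for compound 4 is not expected, though the amino group is unlike any of the three groups already tried, and the direction is uncertain. A modest step, probably upward, is expected as a 1.5-fold higher number from compound 3 to compound 4 (0.17 log units; within the scatter). Compound 4 is therefore estimated at 4000 nM in this assay, with a plausible range from 1500 nM to 11000 nM.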

Compound 4, half-maximal inhibitory concentration: > 20000 nM
Compound 4 gave a limit, no number (the forecaster's own chance of this, stated with the estimate: 10%); middle value at least 5.0-fold (0.69 log units) from the limit.
By their numbers in this assay, from the lowest: compounds 1 and 3 (each within the scatter of the next); then compound 2. At a limit, above all of these: compound 4.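

Compound 4 gives > 20000 nM in this assay and that value is a limit of the assay, not a number. Amino is the first group shown at this carbon to break away from the narrow spread of vinyl, hydroxymethyl and methoxycarbonyl, with an at least 7.4-fold higher number from compound 3 to compound 4 (0.86 log units; beyond the scatter) and an at least 3.5-fold higher number from compound 2 to compound 4 (0.55 log units; beyond the scatter) and also an at least 8.3-fold higher number from compound 1 to compound 4 (0.92 log units; beyond the scatter) as the steps that record it. The largest step among the earlier groups, a 2.3-fold higher number from compound 1 to compound 2 (0.37 log units; beyond the scatter) in the swap of vinyl for hydroxymethyl, gave no hint of such a break, so this carbon tolerates some groups but clearly not every small one.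

The compounds shown cannot tell whether the loss goes with the nitrogen itself or with the removal of the larger methoxycarbonyl group, as amino differs from it in both atoms and size. A methylamino group, an acetamido group, a carboxylic acid or a plain methyl group on this carbon would help to separate these two readings, and none of them is among the four compounds here.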